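The compounds below may be only part of what the source reports. "The series", "measured", "known", "first", "only" and "open" are said of these compounds alone.

Of the compounds shown here, three built on a shared core have been tested in an ADME assay on A549 cells (Homo sapiens) for cytotoxicity, read by CellTiter-Glo; a lower number here means that less compound is tolerated, a higher number that more compound is tolerated. Compound 1 `Cc1c(Cc2ccc(F)cc2F)c(=O)oc2cc(OCC(O)CN3CCC(C(N)=O)CC3)ccc12` carries a 2,4-difluorophenyl group on a saturated chain carbon bound to an aromatic carbon; in this assay compound 1 reaches only the limit of the measurement, > 100000 nM, which is not a number. Compound 2 `Cc1c(Cc2ccc(OC(F)(F)F)cc2)c(=O)oc2cc(OCC(O)CN3CCC(C(N)=O)CC3)ccc12` carries 4-(trifluoromethoxy)phenyl in the same place, and in this assay compound 2 gives 68200 nM. Compound 3 `Cc1c(Cc2cccc3ccccc23)c(=O)oc2cc(OCC(O)CN3CCC(C(N)=O)CC3)ccc12` carries naphthalen-1-yl there, and in this assay compound 3 gives 42400 nM. Going by the values given here, compound 2 and compound 3 sit within the usual scatter of each other, a 1.6-fold lower number from compound 2 to compound 3 (0.21 log units; within the scatter), and the only other value is a limit. From compound 1 the steps are an at least 1.4-fold lower number from compound 1 to compound 2 (0.16 log units; that floor lies within the scatter) and an at least 2.3-fold lower number from compound 1 to compound 3 (0.37 log units; beyond the scatter); the limit of > 100000 nM in this assay, at which 1 of the 3 values shown sits, means each of them is only a floor.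

Compound 4 `Cc1c(Cc2ccc(-c3ccc(C(F)(F)F)cc3)cc2)c(=O)oc2cc(OCC(O)CN3CCC(C(N)=O)CC3)ccc12` differs from compound 2 by 4-(trifluoromethyl)phenyl in place of trifluoromethoxy on an aromatic carbon. Of the measured steps, the closest in kind, swapping one ring for a larger ring system, is an at least 2.3-fold lower number from compound 1 to compound 3 (0.37 log units; beyond the scatter), while a 1.6-fold lower number from compound 2 to compound 3 (0.21 log units; within the scatter) shows that exchanging 4-(trifluoromethoxy)phenyl for naphthalen-1-yl made little difference. A modest downward step is therefore expected, a 1.7-fold lower number from compound 2 to compound 4 (0.23 log units; within the scatter). Compound 4 is estimated at 40000 nM, with a range from 15000 nM to 100000 nM.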

Compound 4, half-maximal cytotoxic concentration: > 100000 nM
Compound 4 ended at the assay's limit (the forecaster's own chance of this, stated with the estimate: 15%); at least 2.5-fold (0.39 log units) between middle value and limit.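

Adding a whole aromatic ring at this aromatic carbon, with 4-(trifluoromethyl)phenyl in place of trifluoromethoxy, does not bring the number in this assay down: the change gives an at least 1.4-fold higher number from compound 2 to compound 4 (0.16 log units; that floor lies within the scatter). The earlier compounds shown here only exchanged one complete group for another on the saturated chain carbon, whereas this change alters the group para to a large group and shows that a much larger substituent, with a ring where there was none, still leaves compound 4 tolerated up to the assay's limit. That floor does not establish a real rise from compound 2 to compound 4, and the true number for compound 4 remains unknown, as the ceiling now limits what can be read from this series: the limit of > 100000 nM in this assay, at which 2 of the 4 values shown sit.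

A plain phenyl in place of 4-(trifluoromethyl)phenyl would separate the part played by the added ring from that of the trifluoromethyl group on it. On these data alone, it also remains open whether an amine or a carboxylic acid on the added ring would bring the number down from the limit.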